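Dimethylamino in place of acetyl on a shared core

A few compounds are considered here, and "the series" means these few. Any claim that something is new, unique, unknown or untested is made for them only; others in the source may bear on it.

The shared core of compound 1 `COc1cc(C)cc(-c2c(-c3ccnc(-c4ccc(C(C)=O)cc4)c3)cnn2CC#N)c1` carries an acetylphenyl group. In a functional assay on OVCAR-8 cells (Homo sapiens) for inhibition, read by sulforhodamine B assay, with a stated time of 48 h (a lower number here means that less compound is tolerated, a higher number that more compound is tolerated), compound 1 reaches only a limit of the method, > 100000 nM. Compound 2 `Cc1cc(O)cc(-c2nn(CC#N)cc2-c2ccnc(-c3ccc(Oc4ccccc4)cc3)c2)c1` has a phenoxy group on the corresponding ring; in this assay compound 2 gives 21900 nM. Compound 3 `Cc1cc(O)cc(-c2nn(CC#N)cc2-c2ccnc(-c3ccc(N(C)C)cc3)c2)c1` replaces that phenoxy with dimethylamino. In this assay compound 3 again reports a limit, > 100000 nM. For the measured compounds named here, the one measured step that bears on the present change is an at least 4.5-fold higher number from compound 2 to compound 3 (0.65 log units; beyond the scatter), brought about by dimethylamino in place of phenoxy on an aromatic carbon. Compound 4 `COc1cc(C)cc(-c2c(-c3ccnc(-c4ccc(N(C)C)cc4)c3)cnn2CC#N)c1` arises from compound 1 by dimethylamino in place of acetyl on an aromatic carbon. Because compound 1 already sits at the limit of > 100000 nM in this assay, at which 2 of the 3 values shown sit, no step upward can be shown by this method, and the related change in the measured pair points nowhere lower. Going by the values given here, the analyst therefore expects no step in this assay beyond the scatter, that is a step that the limit leaves unreadable from compound 1 to compound 4. For compound 4 the analyst estimates 150000 nM, between 60000 nM and 400000 nM, most likely reported once more as a limit.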

Compound 4, concentration lethal to 50% of the cells: > 100000 nM
Compound 4 gave a limit, no number (the forecaster's own chance of this, stated with the estimate: 85%); the middle value does not contradict the limit.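

No step from compound 1 to compound 4 can be read in this assay, as both report only a limit: the limit of > 100000 nM in this assay, at which 3 of the 4 values shown sit.

The compounds shown leave open whether dimethylamino in place of acetyl on the shared core changes the lethal concentration at all.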